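A few compounds are considered here, and "the series" means these few. Any claim that something is new, unique, unknown or untested is made for them only; others in the source may bear on it.

Going by the values given here, in an ADME assay on microsomes from liver (Mus musculus) for metabolic stability, with a stated time of 10 min (a lower number here means that less of the compound is left, a higher number that more of the compound is left), compound 1 `C[C@]1(C(=O)N2CC[C@](c3ccc(C(F)(C(F)(F)F)C(F)(F)F)cc3)(S(=O)(=O)c3ccc(F)cc3)C2)CC[C@H](C(=O)O)CC1` gives 95%, the only single number available. Compound 2 `O=C(O)C1CCC(O)(C(=O)N2CC[C@](c3ccc(C(F)(C(F)(F)F)C(F)(F)F)cc3)(S(=O)(=O)c3ccc(F)cc3)C2)CC1` has two entries, 99%; 98% (2 entries), which lie within the usual scatter of the value for compound 1, and compound 3 `O=C(O)C12CCC(C(=O)N3CC[C@](c4ccc(C(F)(C(F)(F)F)C(F)(F)F)cc4)(S(=O)(=O)c4ccc(F)cc4)C3)(CC1)C2` has the entry "not determined" (no result reported). Compound 4 `O=C(O)C12CCC(C(=O)N3CC[C@](c4ccc(C(F)(C(F)(F)F)C(F)(F)F)cc4)(S(=O)(=O)c4ccc(F)cc4)C3)(CC1)OC2` keeps the shared core but replaces the 4-carboxy-1-methylcyclohexyl group of compound 1, on a carbonyl carbon: a group of 11 heavy atoms (8 carbon, 3 oxygen; one six-membered non-aromatic ring of carbon only, one six-membered non-aromatic ring with 1 hetero atom) in place of a group of 10 heavy atoms (8 carbon, 2 oxygen; one six-membered non-aromatic ring of carbon only), on a carbonyl carbon. Among the compounds with values here, no measured step covers this change, so no shift beyond the scatter is expected in this assay, in either direction. The estimated a number 2 percentage points lower from compound 1 to compound 4 (within the scatter) stays small. For compound 4 the expected value is 93%, with an estimated range from 78% to 100%.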

Compound 4, percent of the compound remaining: 94%
Compound 4: the middle estimate sits 1 percentage points below what was measured; the measured number falls inside the stated range.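

In this assay, going by these compounds alone, the first measured step at this position, on a carbonyl carbon whose other neighbour is an amide-type nitrogen in a ring, gives a number 1 percentage points lower from compound 1 to compound 4 (within the scatter). The 4-carboxy-1-methylcyclohexyl group can therefore give way to a group with a second six-membered ring holding one hetero atom without a shift beyond the scatter. Repeat readings of a single compound also lie close together: the several entries of compound 2 in this assay, 99%; 98% (2 entries)

Every compound shown carries a carboxylic acid on this group. Going by these compounds, how a primary amine or a tetrazole in its place would read in this assay stays open.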